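The source may report more compounds than this note shows. Statements on the series, on what has been measured and on what is new or still open speak of the compounds shown alone.

Notes on the series. In a functional assay on HeLa cells (Homo sapiens) for inhibition, read by sulforhodamine B assay, with a stated time of 48 h (a lower number here means a stronger inhibitor of growth, a higher number a weaker inhibitor of growth), compound 1 `Cc1cc2c(cc1C)C(Cl)=C(/C=N/NC(=O)c1ccccc1)CCC2` gives > 100000 nM, which is a limit of the assay and not a number. Compound 2 `Cc1cc2c(cc1C)C(Cl)=C(/C=N/NC(=O)c1ccccc1N)CCC2` likewise stands at a limit in this assay, at > 100000 nM. Within the data shown here, the one measured step, a step that the two limits leave unreadable from compound 1 to compound 2, therefore cannot be read; both of its ends sit at the limit of > 100000 nM in this assay, at which 2 of the 2 values shown sit. On the numbers shown compound 2 stands nowhere more definite than that limit. Compound 3 `Cc1cc2c(cc1C)C(Cl)=C(/C=N/NC(=O)c1cccc(I)c1)CCC2` differs from compound 2 by 3-iodophenyl in place of 2-aminophenyl on a carbonyl carbon. Among the measured compounds shown here, no measured step bears on a change of this kind; the only step is unreadable. With both measured compounds at the limit, compound 3 is expected to stay near that limit, with a number no higher from compound 2 to compound 3 (the limit leaves the size open) meaning no step beyond the scatter. The estimate for compound 3 in this assay is 100000 nM, between 30000 nM and 300000 nM, most likely reported again only as a limit.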

Compound 3, concentration for 50% growth inhibition: > 100000 nM
Compound 3: only a limit was reported (the forecaster's own chance of this, stated with the estimate: 80%); the middle value lies on the limit itself.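

Among these compounds, compound 3 is again only a limit in this assay and not a number, so no step among compound 1, compound 2 and compound 3 can be read: the limit of > 100000 nM in this assay, at which 3 of the 3 values shown sit. The compounds shown leave open whether 2-aminophenyl and 3-iodophenyl differ at all in their effect on growth.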